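Replacing a Bromine with a Methylphenyl Ring

The compounds below may be only part of what the source reports. "The series", "measured", "known", "first", "only" and "open" are said of these compounds alone.

Of the compounds shown here, two have been measured so far. Compound 1 `O=C(O)CCc1ccc(OCc2cccc(Br)c2)cc1` in a functional assay on 1321-N1 cells for agonist activity at Free fatty acid receptor 1 (Homo sapiens), read by calcium flux (on this read-out lower numbers stand for an effect already at smaller amounts and higher numbers for an effect only at larger amounts of compound), gives 89.1 nM. Compound 2 `O=C(O)CCc1ccc(NCc2cccc(-c3ccccc3)c2)cc1`, which joins its two aromatic parts through a different linker and carries a phenyl group, gives in this assay 53.7 nM. Of these two numbers compound 1 holds the highest, but its gap to compound 2 lies within the usual scatter of repeated measurements, so the two cannot be told apart on this read-out.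

Compound 3 `Cc1ccc(-c2cccc(COc3ccc(CCC(=O)O)cc3)c2)cc1` keeps the core of compound 1 and differs in one place: 4-methylphenyl in place of bromo on an aromatic carbon of a six-membered aromatic ring of carbon only, meta to a large group. Among the measured compounds shown here, no step between two measured compounds shows how this exchange acts on its own. For the measured compounds named here, what can be said is that compound 2, the one compound here with an added phenyl ring, gives 53.7 nM, a number close to that of compound 1. The expected step of a 1.8-fold lower number from compound 1 to compound 3 (0.25 log units; within the scatter) is therefore small, downward if anything, and most likely within the scatter. Compound 3 is estimated to give about 50 nM in this assay, with a range from 15 nM to 200 nM.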

Compound 3, half-maximal effective concentration: 490 nM
For compound 3 the middle estimate is 9.8-fold (0.99 log units) below the measured one; measured number outside the range, above it.
By their numbers in this assay, from the lowest: compounds 2 and 1 (each within the scatter of the next); then compound 3.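

In this assay, putting 4-methylphenyl in place of bromo on the core of compound 1 gives a 5.5-fold higher number from compound 1 to compound 3 (0.74 log units; beyond the scatter). Among the compounds shown here, this is the first step here that changes a single place, and it lies beyond the scatter, so at this position the exchange of a lone bromine for a ring-bearing group of 7 heavy atoms has a real, though modest, cost on this read-out. The cost is not a complete loss, since compound 3 still gives a measurable number of 490 nM, but nothing available explains why the number rises with this exchange.

As far as these compounds go, the exchange brings in a ring and a methyl group together, so it remains open whether the ring alone accounts for the step or the methyl group on it contributes, a question that an unsubstituted phenyl group on the oxygen-linked core of compound 1 would address. From the compounds shown here alone, it is also open how other groups would behave at this position, for example chloro, or a 4-methoxyphenyl or 4-fluorophenyl ring in place of the 4-methylphenyl.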